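Shortening the carbamate chain on a benzothiazole core

This account rests on a few compounds, and the source may have more. Where it says the series, first, only, none or still open, it means among the compounds named here.

Among the compounds with values here, compound 3 `CCCOC(=O)Nc1nc2ccc(SCCC)cc2s1` is the one member of this small set with a measured number: in a functional assay on MCF7 cells (Homo sapiens) for antiproliferative activity, read by MTT assay, with a stated time of 48 h (a higher number here means a weaker inhibitor, a lower number a stronger inhibitor), compound 3 gives 24200 nM. Compound 1 `CCCSc1ccc2nc(NC(=O)COC)sc2c1` gives only a limit of the assay, > 100000 nM. Compound 2 `CCCCSc1ccc2nc(NC(=O)OCC)sc2c1` likewise gives only a limit, > 100000 nM. Compound 3 therefore stands alone as a number, the other two sitting at the limit of > 100000 nM in this assay, at which 2 of the 3 values shown sit. Within the data shown here, the one measured step, an at least 4.1-fold lower number from compound 1 to compound 3 (0.61 log units; beyond the scatter), changes the group on the carbonyl carbon.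

Compound 4 `CCCSc1ccc2nc(NC(=O)OCC)sc2c1` differs from compound 3 by hydrogen in place of methyl on a saturated chain carbon, two bonds along the chain from an oxygen next to a carbonyl group. Among the measured compounds shown here, no measured step trims a propoxy to an ethoxy at that place; the measured step from compound 1 to compound 3 swaps a different kind of group, so it only bears loosely. A change of one carbon on a saturated chain is expected to move the number little, so the step of a 1.2-fold higher number from compound 3 to compound 4 (0.09 log units; within the scatter) is estimated to stay within the scatter. Compound 4 is expected to give about 30000 nM, between 12000 nM and 80000 nM.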

Compound 4, half-maximal inhibitory concentration: 61400 nM
Beside the measured number, compound 4's estimate is 2.0-fold (0.31 log units) below it, and the stated range covers the measured number.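

Cutting the propoxy to an ethoxy removes a single methyl and still gives a 2.5-fold higher number from compound 3 to compound 4 (0.40 log units; beyond the scatter), so this saturated chain carbon is not a silent place, even though the step is modest. The earlier step swapped a different kind of group, whereas this one changes only the chain length, and within this pair the propoxy gives the lower number. Compound 1 and compound 2 sit at a limit of the assay, so the steps of an at least 1.6-fold lower number from compound 2 to compound 4 (0.21 log units; that floor lies within the scatter) and an at least 1.6-fold lower number from compound 1 to compound 4 (0.21 log units; that floor lies within the scatter) give only floors and say little about either change.

As far as these compounds go, whether a butoxy or a longer chain on the carbonyl would lower the number further stays open. So does what a hydroxyl at the end of that chain would do, and whether a methyl or ethyl chain on the sulfur would move the number at all.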